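Dropping the amino linker before the triazole

The source may hold more compounds than are shown below. What is called first, only, known or untested is meant among the compounds shown, and "the series" means these compounds.

Compound 1 `CC(C)C(Nc1nnc[nH]1)c1ccc(-c2ccc3cccc(F)c3c2)[nH]c1=O`: 22 nM
Compound 2 `CCn1ncc2c(F)cc(-c3ccc(C(CC)(CC)c4nncn4C)c(=O)[nH]3)cc21`: 54 nM

Of the compounds shown here, two have been measured in an assay on CHO cells for displacement of a labelled ligand from prostaglandin E2 receptor EP3 subtype (Homo sapiens), read by radioligand binding; on this read-out higher numbers stand for weaker inhibition and lower numbers for stronger inhibition. Compound 1 gives 22 nM, the lower of the two numbers, and compound 2 gives 54 nM; the gap between them lies beyond the usual scatter of repeated measurements.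

Compound 3 `CC(C)C(c1nnc[nH]1)c1ccc(-c2ccc3cccc(F)c3c2)[nH]c1=O` is not yet measured. It differs from compound 1 in one place: 4H-1,2,4-triazol-3-yl in place of (4H-1,2,4-triazol-3-yl)amino on a saturated chain carbon bound to an aromatic carbon and a saturated chain carbon. In plain words, the triazole ring is now attached directly to the carbon that carries the isopropyl group, and the nitrogen bridge with its hydrogen is gone. Compound 2 shows that a directly attached triazole on this kind of carbon can still give a useful number, so a large loss is not expected. The step of a 1.8-fold higher number from compound 1 to compound 3 (0.26 log units; within the scatter) is estimated as a small weakening, possibly within the scatter. Compound 3 is therefore expected to give about 40 nM in this assay, with a likely range from 12 nM to 130 nM.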

Compound 3, inhibition constant: 12 nM
Compound 3: middle estimate off by 3.3-fold (0.52 log units), on the high side; the measured number falls inside the stated range.
By their numbers in this assay, from the lowest: compounds 3 and 1 (each within the scatter of the next); then compound 2.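

In this assay, taking out the nitrogen bridge with its hydrogen gives a 1.8-fold lower number from compound 1 to compound 3 (0.26 log units; within the scatter), so the two compounds cannot be told apart on this read-out. At this saturated chain carbon, then, the triazole ring does not need the amino link to keep a number of this size, even though the count of hydrogen-bond donors goes from 2 to 1 and the count of acceptors from 3 to 2. No measurement at hand explains why this change leaves the number so little altered.

The compounds shown leave open whether a different group on this carbon, such as a carboxylic acid or a primary amine, would serve as well as the triazole. They also leave open whether a longer chain in place of the isopropyl group would keep the number.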